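Trading Cyclopentyl for Allyl on the Shared Core

The compounds below may be only part of what the source reports. "The series", "measured", "known", "first", "only" and "open" are said of these compounds alone.

Of the compounds shown here, two with the same core have numbers so far. In a functional assay on HL-60 cells (Homo sapiens) for inhibition (on this read-out higher numbers stand for weaker inhibition and lower numbers for stronger inhibition), compound 1 (`COc1ccc(-c2cc(=O)n(C3CC3)nc2-c2ccc(OC)cc2)cc1`), with a cyclopropyl on an aromatic nitrogen, gives 7980 nM while compound 2 (`COc1ccc(-c2cc(=O)n(C3CCCC3)nc2-c2ccc(OC)cc2)cc1`), with a cyclopentyl there, gives 510 nM and holds the lower of the two numbers, which means the stronger inhibition. The next structure, compound 3 (`C=CCn1nc(-c2ccc(OC)cc2)c(-c2ccc(OC)cc2)cc1=O`), has allyl in place of cyclopentyl on an aromatic nitrogen. For the measured compounds named here, only one measured step bears on this change, a 16-fold lower number from compound 1 to compound 2 (1.19 log units; beyond the scatter) and it shows that the group on this nitrogen can move the number a long way. Allyl is neither of the two groups tested, and one step is thin evidence. Going by the values given here, since the only other group tested gave the higher number, a move upward is expected in this assay and it should be smaller than the measured step. The estimated change is a 4.9-fold higher number from compound 2 to compound 3 (0.69 log units; beyond the scatter) and lies beyond the scatter. Compound 3 is expected near 2500 nM with a likely range from 800 nM to 8000 nM in this estimate.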

Compound 3, half-maximal inhibitory concentration: > 100000 nM
Compound 3 was reported as a limit; the forecaster's own chance of this, stated with the estimate: 5%; middle value at least 40-fold (1.60 log units) from the limit.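

In this assay compound 3 stands at a limit and not at a number: the limit of > 100000 nM in this assay, at which 1 of the 3 values shown sits. Allyl in place of cyclopentyl gives an at least 190-fold higher number from compound 2 to compound 3 (2.29 log units; beyond the scatter), and allyl in place of cyclopropyl gives an at least 12-fold higher number from compound 1 to compound 3 (1.09 log units; beyond the scatter), so the open chain sits on the weak side of both ring-bearing compounds by a margin beyond the scatter. The earlier pair showed only that the size of the carbon ring on this aromatic nitrogen can move the number a long way, whereas compound 3 shows that this position can lose nearly all measurable inhibition with a small change of group, and that the weakest of the three is not the smallest ring but the group with no ring at all.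

Three groups cannot tell whether the missing ring, the double bond or the smaller number of carbons goes with this drop, and a saturated propyl chain set against allyl would separate the last two. Nor do they show whether the trend among the rings carries on, which a cyclohexyl or benzyl group on the same nitrogen would test, and the true value of compound 3 stays unknown behind its limit.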